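Vero Cell Cytotoxicity Notes on a Three-Compound Series

This account rests on a few compounds, and the source may have more. Where it says the series, first, only, none or still open, it means among the compounds named here.

Compound 1 `CSc1ccc(-c2nc3sc(C(F)(F)F)nn3c2-c2ccccc2)cc1` carries a trifluoromethyl group on the shared core. In an ADME assay on Vero cells (Chlorocebus sabaeus) for cytotoxicity, read by MTT assay, with a stated time of 72 h (a lower number here means a stronger inhibitor, a higher number a weaker inhibitor), compound 1 gives 140000 nM, a weak effect on the cells. Among the compounds with values here, compound 2 `CSc1ccc(-c2nc3sc(-c4ccc(F)cc4)nn3c2-c2ccccc2)cc1` replaces the trifluoromethyl group with a 4-fluorophenyl group; in this assay compound 2 gives "not determined" (no result reported), so no number can be placed beside it and the series so far rests on a single measured value. Compound 3 `COc1ccc(-c2nn3c(-c4ccccc4)c(-c4ccc(SC)cc4)nc3s2)cc1` is the next member. The change from compound 2 to compound 3 is methoxy in place of fluoro on an aromatic carbon. Within the data shown here, no measured step exists between any two compounds here, so the size of the step in this assay from compound 2 to compound 3 cannot be read off; the expectation is for no change beyond the usual scatter, with compound 3 staying in the weak range where compound 1 sits at 140000 nM. Compound 3 is expected to give about 150000 nM in this assay, within a range from 50000 nM to 400000 nM, with a real chance that only a limit is reported.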

Compound 3, half-maximal inhibitory concentration: 135000 nM
For compound 3 the middle estimate is 1.1-fold (0.05 log units) above the measured one, and the stated range covers the measured number.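

In this assay the position that holds trifluoromethyl in compound 1 now has a measured aromatic member, the 4-methoxyphenyl group of compound 3, and the change between them reads as (a 1.0-fold lower number from compound 1 to compound 3 (0.02 log units; within the scatter)). A trifluoromethyl group and a 4-methoxyphenyl group at this position therefore give the same reading within the scatter, so this one pair shows no sensitivity of the number to the change, and compound 3 stays in the weak range of compound 1. Steps involving compound 2 cannot be read, which leaves the change from fluoro to methoxy on the aromatic carbon without a size, and nothing at hand bears on why compound 1 and compound 3 agree.

The compounds shown leave open whether any group at this position moves the number at all, for example a primary amine or a carboxylic acid on the same phenyl ring, or a longer alkyl chain in place of trifluoromethyl. They also leave open whether the phenyl group and the methylthio group elsewhere on the shared core matter in this read-out, as both stay the same across compound 1, compound 2 and compound 3.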